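Moving from Chloro to Methoxy on the Nitrogen-Bound Ring

A few compounds are considered here, and "the series" means these few. Any claim that something is new, unique, unknown or untested is made for them only; others in the source may bear on it.

Of the compounds shown here, two have so far been measured in an assay on HEK293 cells for displacement of a labelled ligand from metabotropic glutamate receptor 5 (Rattus norvegicus); on this read-out lower numbers stand for stronger inhibition and higher numbers for weaker inhibition. Compound 1, `O=C(Nc1cc(-c2ccccc2Cl)nn1-c1ccccc1)c1ccccc1`, does not reach a numerical value: in this assay compound 1 gives > 10000 nM, which is a limit of the assay rather than a number. Compound 2, `O=C(Nc1cc(-c2ccccc2)nn1-c1ccccc1Cl)c1ccccc1`, carries its chlorine on the ring attached to nitrogen instead, and in this assay compound 2 gives 500 nM. Compound 2 therefore stands as the only entry with a real number. The other entry is the limit recorded as the limit of > 10000 nM in this assay, at which 1 of the 2 values shown sits.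

Compound 3, `COc1cccc(-n2nc(-c3ccccc3)cc2NC(=O)c2ccccc2)c1`, differs from compound 2 in one place: 3-methoxyphenyl in place of 2-chlorophenyl on an aromatic nitrogen. Among the compounds with values here, no measured pair shows what a change at this position does, so the size of the step can only be judged roughly. A moderate move toward weaker binding is expected, though one that may not clearly exceed the scatter of repeated measurements. The expected step is a 3.0-fold higher number from compound 2 to compound 3 (0.48 log units; beyond the scatter). Compound 3 is estimated to give about 1500 nM in this assay, within a range from 300 nM to 8000 nM.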

Compound 3, inhibition constant: 2100 nM
The estimate for compound 3 lay 1.4-fold (0.15 log units) below the measured number, and the stated range covers the measured number.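

In this assay, within the data shown here, putting 3-methoxyphenyl in place of 2-chlorophenyl on the aromatic nitrogen gives a 4.2-fold higher number from compound 2 to compound 3 (0.62 log units; beyond the scatter), the first measured step at this position. The change weakens binding modestly, yet compound 3 still gives a real number, so this position accepts a different group on the ring without the value being lost to the end of the measurable range. Compound 1 remains the only entry that gives a limit of the assay rather than a number: the limit of > 10000 nM in this assay, at which 1 of the 3 values shown sits.

This single step changes two things at once, the kind of group on the ring (chlorine for methoxy) and where that group sits, so the compounds shown cannot separate one effect from the other; 3-chlorophenyl or 2-methoxyphenyl on the same nitrogen would pull the two apart. From the compounds shown here alone, it also stays open how binding would respond to a ring on this nitrogen carrying an amine, a carboxylic acid or a longer chain such as butoxy, since a single step says little about how far the trend extends.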